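A few compounds are considered here, and "the series" means these few. Any claim that something is new, unique, unknown or untested is made for them only; others in the source may bear on it.

All the compounds here share one core and differ in the group on an aromatic nitrogen. In a functional assay on HT-29 cells (Homo sapiens) for antiproliferative activity, read by MTT assay, with a stated time of 72 h (a higher number here means a weaker inhibitor, a lower number a stronger inhibitor), compound 1 (`CCn1ccnc1-c1cc(OC)c(OC)c(OC)c1`) gives > 100000 nM, which is a limit and not a number. Going by the values given here, compound 2 (`CCCCCn1ccnc1-c1cc(OC)c(OC)c(OC)c1`) gives 60100 nM, the only true number so far. Compound 3 (`COc1cc(-c2nccn2Cc2ccccc2)cc(OC)c1OC`), which carries a benzyl, gives > 100000 nM, again only a limit. Compound 3 therefore has no exact starting value and stands at the limit of > 100000 nM in this assay, at which 2 of the 3 values shown sit.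

Compound 4 (`COc1cc(-c2nccn2-c2ccc(Br)cc2)cc(OC)c1OC`), not yet measured, has 4-bromophenyl in place of benzyl on an aromatic nitrogen.

Among the compounds with values here, three measured steps concern this same group. Extending the chain gave an at least 1.6-fold lower number from compound 1 to compound 2 (0.22 log units; that floor lies within the scatter). Replacing butyl with phenyl gave an at least 1.6-fold higher number from compound 2 to compound 3 (0.22 log units; that floor lies within the scatter), while replacing methyl with phenyl gave a step that the two limits leave unreadable from compound 1 to compound 3. None of them puts a ring straight onto the nitrogen or brings in bromine, so they offer only weak guidance. Compound 2 at 60100 nM does show that this core can give a value within the reach of this assay. A modest move towards a lower number is therefore expected, namely an at least 2.5-fold lower number from compound 3 to compound 4 (0.39 log units; beyond the scatter). A further limit would be no surprise. For compound 4 the estimated value is 40000 nM, with an expected range from 5000 nM to 100000 nM.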

Compound 4, half-maximal inhibitory concentration: 7700 nM
The estimate for compound 4 lay 5.2-fold (0.72 log units) above the measured number; measured number inside the range.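

In this assay, compound 4 is the only compound shown whose aromatic nitrogen carries a ring with no saturated chain carbon attached to that nitrogen, and this change gave an at least 12-fold lower number from compound 3 to compound 4 (1.11 log units; beyond the scatter). A chain does not match this ring: the move from pentyl to 4-bromophenyl gave a 7.8-fold lower number from compound 2 to compound 4 (0.89 log units; beyond the scatter), the move from ethyl gave an at least 12-fold lower number from compound 1 to compound 4 (1.11 log units; beyond the scatter), and compound 4 is therefore the strongest of the four. Benzyl and 4-bromophenyl have the same count of heavy atoms and each holds one six-membered aromatic ring, so that count alone does not decide the value here, and the steps starting from compound 3 and compound 1 are only floors: the limit of > 100000 nM in this assay, at which 2 of the 4 values shown sit.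

Two things change together in compound 4, the way the ring is attached and the bromine, so it remains open which of them accounts for the step. From the compounds shown here alone, a plain phenyl or a 4-chlorophenyl on the same nitrogen would separate the two, and it is also open how an amine or a carboxylic acid on that ring would behave.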